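The compounds below may be only part of what the source reports. "The series", "measured", "known", "first", "only" and "open" are said of these compounds alone.

Compound 2 `CCOc1ccc(CN(Cc2ccc(C(C)(C)C)cc2)Cc2cc3cc(C)ccc3[nH]c2=O)cc1` was tested in a toxicity assay on MDCK cells (Canis lupus familiaris) for cytotoxicity, read by crystal violet staining, with a stated time of 48 h; a higher number here means that more compound is tolerated, a lower number that less compound is tolerated. In this assay compound 2 reaches only a limit of the assay, > 10000 nM, so no number is known for it. Compound 1 `CCc1ccc2[nH]c(=O)c(CN(Cc3cccc(F)c3)Cc3ccc4ccccc4c3)cc2c1` likewise gives a limit in this assay, > 5000 nM. Compound 2 therefore stands at the limit of > 10000 nM in this assay, at which 1 of the 2 values shown sits, while compound 1 sits at the limit of > 5000 nM in this assay, at which 1 of the 2 values shown sits. Compound 3 `Cc1ccc2[nH]c(=O)c(CN(Cc3ccc(C(C)(C)C)cc3)C(C)c3ccc(OC(F)F)cc3)cc2c1` differs from compound 2 by one change, (1-(4-(difluoromethoxy)phenyl)ethyl in place of 4-ethoxybenzyl on an amine nitrogen). Going by the values given here, because both known values in this assay are limits, no measured step can guide the size or direction of the change expected from compound 2 to compound 3, and no shift beyond the usual scatter is expected here a number no higher from compound 2 to compound 3 (the limit leaves the size open). Compound 3 is expected to tolerate about 10000 nM in this assay, within a range from 5000 nM to 20000 nM, most likely again reported as a limit.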

Compound 3, half-maximal cytotoxic concentration: > 5000 nM
Compound 3 was reported as a limit (the forecaster's own chance of this, stated with the estimate: 70%); the middle value lies beyond the limit too.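

Going by these compounds alone, compound 2 and compound 3 both give only limits in this assay, so no step between them can be read. The compounds shown leave open at what concentration any of them actually becomes toxic to the cells.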